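The compounds below may be only part of what the source reports. "The series", "measured", "known", "first", "only" and "open" are said of these compounds alone.

Working notes on the series. Compound 1 `COC(=O)[C@@]1(C)CCC=C2[C@@H]1CC[C@@H](C)[C@]2(C)Cc1c[nH]c2c(Cl)cccc12`, compound 2 `COC(=O)[C@@]1(C)CCC=C2[C@@H]1CC[C@@H](C)[C@]2(C)Cc1c(C)[nH]c2ccccc12` and compound 3 `COC(=O)[C@@]1(C)CCC=C2[C@@H]1CC[C@@H](C)[C@]2(C)Cc1c(C)[nH]c2c(Br)cccc12` share one core. In a functional assay on SW1573 cells (Homo sapiens) for inhibition, read by sulforhodamine B assay, with a stated time of 48 h (a higher number here means a weaker inhibitor of growth, a lower number a stronger inhibitor of growth), compound 1 gives 14000 nM, compound 2 gives 14000 nM and compound 3 gives 25000 nM. Compound 3 has the highest of the three numbers, yet its gaps to compound 1 and to compound 2 both fall within the scatter, so no order among the three can be read. Among the measured compounds shown here, the one single-point step measured so far, a 1.8-fold higher number from compound 2 to compound 3 (0.25 log units; within the scatter), puts bromo on an aromatic carbon and stays within the scatter.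

Compound 4 `COC(=O)[C@@]1(C)CCC=C2[C@@H]1CC[C@@H](C)[C@]2(C)Cc1c(C)[nH]c2c(Cl)cccc12` differs from compound 3 by chloro in place of bromo on an aromatic carbon. For the measured compounds named here, no measured pair swaps bromo for chloro; compound 1 carries chloro on an aromatic carbon but lacks the methyl found in compound 3, so it bears on the step only loosely, and compound 1 at 14000 nM sits within the scatter of compound 3 anyway. Given that the halogen step from compound 2 to compound 3 stayed within the scatter, the swap is expected to move nothing beyond it. Compound 4 is therefore expected to give 18000 nM in this assay, with a range from 7000 nM to 45000 nM. The step this implies, a 1.4-fold lower number from compound 3 to compound 4 (0.14 log units; within the scatter), is expected to remain within the scatter.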

Compound 4, concentration for 50% growth inhibition: 19000 nM
The estimate for compound 4 lay 1.1-fold (0.02 log units) below the measured number, within the range that was stated.
By their numbers in this assay, from the lowest: compounds 1, 2, 4 and 3 (each within the scatter of the next).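

In this assay, the halogen swap on this aromatic carbon of the six-membered aromatic ring gives a 1.3-fold lower number from compound 3 to compound 4 (0.12 log units; within the scatter) and stays within the scatter, so chloro and bromo cannot be told apart here. Chloro in place of hydrogen at the same carbon gives a 1.4-fold higher number from compound 2 to compound 4 (0.13 log units; within the scatter) and also stays within the scatter, so with the earlier bromo step, neither halogen is separated from hydrogen at this position. The series also gains its first single-change reading for methyl in place of hydrogen, a 1.4-fold higher number from compound 1 to compound 4 (0.13 log units; within the scatter) on a different aromatic carbon, and this too stays within the scatter.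

No evidence bearing on these results is available. On these data alone, whether an amine, a carboxylic acid or a longer chain on this aromatic carbon would move the number beyond the scatter remains open.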